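A Dimethylamino Chain Replaces the Branched Acrylamide

The source may hold more compounds than are shown below. What is called first, only, known or untested is meant among the compounds shown, and "the series" means these compounds.

Among the measured compounds shown here, compound 1 `COc1cc2ncnc(N3CCc4ccccc43)c2cc1NC(=O)C=C(C)C` gives 7840 nM in a functional assay on PC-3 cells (Homo sapiens) for antiproliferative activity, read by MTT assay, with a stated time of 72 h (a lower number here means a stronger inhibitor, a higher number a weaker inhibitor), the higher of the two numbers measured, while compound 2 `CC(C)=CC(=O)Nc1cc2c(N3CCc4ccccc43)ncnc2cc1O[C@@H]1CCOC1` gives 4620 nM in this assay; the only measured step, a 1.7-fold lower number from compound 1 to compound 2 (0.23 log units; within the scatter), lies within the scatter. Compound 3 `COc1cc2ncnc(N3CCc4ccccc43)c2cc1NC(=O)/C=C/CN(C)C` differs from compound 1 by 3-(dimethylamino)prop-1-en-1-yl in place of 2-methylprop-1-en-1-yl on a carbonyl carbon. For the measured compounds named here, no measured step touches this part of the shared core, so the change from compound 1 to compound 3 is expected to stay within the scatter, as a 1.6-fold lower number from compound 1 to compound 3 (0.20 log units; within the scatter). Compound 3 is therefore estimated at 5000 nM, in a range from 1500 nM to 16000 nM.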

Compound 3, half-maximal inhibitory concentration: 2190 nM
Compound 3: middle estimate off by 2.3-fold (0.36 log units), on the high side, within the range that was stated.
By their numbers in this assay, from the lowest: compound 3; then compounds 2 and 1 (each within the scatter of the next).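

At this carbonyl carbon, the side chain does register in this assay: 3-(dimethylamino)prop-1-en-1-yl in place of 2-methylprop-1-en-1-yl gives a 3.6-fold lower number from compound 1 to compound 3 (0.55 log units; beyond the scatter). This is the first step shown that lies beyond the scatter, although it is a modest one, and it shows that this position responds more clearly than the oxygen substituent did. Nothing measured here accounts for the drop.

Going by these compounds, whether the amine itself matters remains open, as a piperidine or morpholine in place of the dimethylamino group, or a longer chain carrying it, would show. Also open, on these data alone, is whether the same change holds with oxolan-3-yl on the oxygen.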